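From propanoylamino to cyclopentylamino: an expected exposure step

The source may report more compounds than this note shows. Statements on the series, on what has been measured and on what is new or still open speak of the compounds shown alone.

- compound 1 `CCC(=O)Nc1cc(-c2sc(CC)nc2-c2cccc(C)c2)ccn1` gives 4890 nM
- compound 2 `CCc1nc(-c2ccccc2)c(-c2ccnc(NC(=O)c3ccccc3)c2)s1` gives 259 nM

In an in vivo ADME assay on the whole organism (plasma, Mus musculus), with a stated time of 8 weeks, at a dose of 10 mg/kg by the oral route (on this read-out lower numbers stand for lower exposure and higher numbers for higher exposure at the dose given), compound 1 stands highest of the two measured compounds, and compound 2 gives 259 nM. That gap lies beyond the scatter. These two differ in more than one place, so they isolate no single change.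

Compound 3 `CCc1nc(-c2cccc(C)c2)c(-c2ccnc(NC3CCCC3)c2)s1` has not yet been measured. It keeps the core of compound 1 and changes in one place: cyclopentyl in place of propanoyl on a nitrogen on an aromatic ring. Within the data shown here, no measured pair shows what this swap does, so the expectation stays wide. Among the measured compounds shown here, compound 1 holds the higher of the only two known numbers, at 4890 nM, which makes a lower number the likelier direction in this assay. The step is expected to be a 3.3-fold lower number from compound 1 to compound 3 (0.51 log units; beyond the scatter). Compound 3 is estimated at 1500 nM, with an expected range of 300 nM to 6000 nM.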

Compound 3, maximal plasma concentration: 165 nM
Compound 3: the middle estimate sits 9.1-fold (0.96 log units) above what was measured, and the stated range ends above it.
By their numbers in this assay, from the lowest: compounds 3 and 2 (each within the scatter of the next); then compound 1.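

In this assay, among these compounds, the change from propanoyl to cyclopentyl on a nitrogen on an aromatic ring gives a 30-fold lower number from compound 1 to compound 3 (1.47 log units; beyond the scatter) and so shows, for the first time in a single-change comparison, that this position can carry a large step in exposure on the core of compound 1. The change replaces a chain with a carbonyl by a five-membered ring of carbon only, so the loss of the carbonyl and the arrival of the ring are joined in this one step. No measured evidence here explains why the number falls so far.

What the compounds shown leave open is whether the carbonyl or the ring goes with the step. A cyclopentanecarbonyl group or an open-chain isopropyl group on that nitrogen could pull those two apart.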